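Working notes: 3-carboxyphenyl swap on compound 2

The source may report more compounds than this note shows. Statements on the series, on what has been measured and on what is new or still open speak of the compounds shown alone.

- compound 1 `CC(C)n1nc(C(=O)O)cc1C1CC1c1ccc(OCc2c(-c3c(Cl)cccc3Cl)noc2C2CC2)cc1Cl` measured at 0.8 h
- compound 2 `CC(C)n1nc(C(=O)O)cc1[C@H]1C[C@](O)(c2ccc(OCc3c(-c4c(Cl)cccc4Cl)noc3C3CC3)cc2Cl)C1` measured at 0.6 h

In an ADME assay on the whole organism (strain C57BL/6J) for metabolic stability, with Mus musculus as the target (a lower number here means that the compound disappears faster, a higher number that the compound lasts longer), compound 2 stands at 0.6 h and compound 1 at 0.8 h (two numbers within the usual scatter of each other). Compound 3 `O=C(O)c1cccc([C@H]2C[C@](O)(c3ccc(OCc4c(-c5c(Cl)cccc5Cl)noc4C4CC4)cc3Cl)C2)c1` has yet to be measured. It differs from compound 2 by one change 3-carboxyphenyl in place of 3-carboxy-1-isopropyl-1H-pyrazol-5-yl on a saturated ring carbon. Going by the values given here, both measured compounds carry the 3-carboxy-1-isopropyl-1H-pyrazol-5-yl group, so no measured pair shows what this replacement does. The expectation rests only on the close values of compound 1 at 0.8 h and compound 2 at 0.6 h and stays cautious. A small rise is expected, not clearly beyond the scatter, and a fall cannot be ruled out. The expected change in this assay is a 1.5-fold higher number from compound 2 to compound 3 (0.18 log units; within the scatter) (an estimate only). For compound 3 the estimated half-life is 0.9 h (expected range 0.4 h to 2.2 h).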

Compound 3, half-life: 0.6 h
Compound 3: the middle estimate sits 1.5-fold (0.18 log units) above what was measured; measured number inside the range.
By their numbers in this assay, from the lowest: compounds 2, 3 and 1 (each within the scatter of the next).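

In this assay, going by these compounds alone, the swap of 3-carboxy-1-isopropyl-1H-pyrazol-5-yl for 3-carboxyphenyl on the saturated ring carbon gives no change at the digits printed from compound 2 to compound 3 (within the scatter) in the first measured pair at this position. At this position, on the core of compound 2, a six-membered aromatic ring of carbon only can therefore stand in for a five-membered aromatic ring with 2 hetero atoms, and the isopropyl group can be absent, with the carboxylic acid kept and the half-life within the scatter. Nothing available explains this outcome, so it stands as an observation from a single pair of compounds.

Still open, as far as these compounds go, is what a primary amide or a tetrazole in place of the carboxylic acid on the phenyl ring, or a pyridine ring in place of the phenyl ring, would do to the half-life in this assay at this position. Also open, from the compounds shown here alone, is whether the same 3-carboxyphenyl swap on the core of compound 1 would give a similar result, as a single pair on the core of compound 2 cannot settle how far this finding carries.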